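A few compounds are considered here, and "the series" means these few. Any claim that something is new, unique, unknown or untested is made for them only; others in the source may bear on it.

Measured in a functional assay on HUVEC cells (Homo sapiens) for inhibition; a higher number here means a weaker inhibitor, a lower number a stronger inhibitor:
Compound 1 `COc1cc(/C=C/C(=O)c2cccc(NC(=O)c3ccc(Cl)cc3)c2)ccc1O`: 0.76 ug/mL
Compound 2 `COc1cc(/C=C/C(=O)c2cccc(NC(=O)c3ccco3)c2)ccc1O`: 0.38 ug/mL

For the measured compounds named here, compound 2, at 0.38 ug/mL, lies within the scatter of compound 1, the only other measured compound. Compound 3 `COc1cc(/C=C/C(=O)c2cccc(N)c2)ccc1O` carries hydrogen in place of (furan-2-yl)carbonyl on a nitrogen on an aromatic ring. Going by the values given here, the single measured step, a 2.0-fold lower number from compound 1 to compound 2 (0.30 log units; within the scatter), only exchanges the group on the carbonyl carbon and stays within the scatter. Among the compounds with values here, no measured step removes the whole group, so it offers limited guidance. A modest move to a higher number in this assay is expected, about the size of the scatter. The estimated change is a 2.1-fold higher number from compound 2 to compound 3 (0.32 log units; beyond the scatter). Compound 3 is expected at 0.8 ug/mL, with an estimated range of 0.2 ug/mL to 3.2 ug/mL.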

Compound 3, half-maximal inhibitory concentration: 2.87 ug/mL
Estimate against measurement, compound 3: 3.6-fold (0.55 log units) below; measured number inside the range.
By their numbers in this assay, from the lowest: compounds 2 and 1 (each within the scatter of the next); then compound 3.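

In this assay there is a 7.6-fold higher number from compound 2 to compound 3 (0.88 log units; beyond the scatter) when the (furan-2-yl)carbonyl group leaves the nitrogen, and a 3.8-fold higher number from compound 1 to compound 3 (0.58 log units; beyond the scatter) when the (4-chlorophenyl)carbonyl group leaves it. Exchanging the group on the carbonyl carbon stayed within the scatter, but removing the whole group goes beyond it, so the free amino compound stands apart from both amides. No measurement shown here accounts for this difference.

Going by these compounds, it remains open whether a small acetyl group on this nitrogen would match compound 1 and compound 2, or whether the ring on the carbonyl carbon is needed. On these data alone, a methanesulfonyl group in the same place is equally open.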